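Limits Only: From Carboxyethenyl Amide to Chloromethyl Amide

The source may report more compounds than this note shows. Statements on the series, on what has been measured and on what is new or still open speak of the compounds shown alone.

Of the compounds shown here, three have been measured in an ADME assay on BJ cells (Homo sapiens) for inhibition, with a stated time of 72 h; on this read-out lower numbers stand for an effect already at smaller amounts and higher numbers for an effect only at larger amounts of compound. Compound 1 `O=C(Nc1ccc(Cl)cc1)c1cc([N+](=O)[O-])ccc1Cl` gives only a limit, > 25000 nM. Compound 2 `C/C=C/C(=O)Nc1cccc(-c2nc3ccccc3s2)c1` likewise reaches only a limit, > 25000 nM. Compound 3 `O=C(O)/C=C/C(=O)Nc1cccc(-c2nc3ccccc3s2)c1`, the starting point of the step followed here, also sits at a limit, > 25000 nM. Among the measured compounds shown here, all three values rest at the limit of > 25000 nM in this assay, at which 3 of the 3 values shown sit, so the one step between neighbouring structures, a step that the two limits leave unreadable from compound 2 to compound 3, cannot be read. On the numbers shown, compound 3 therefore stands nowhere distinguishable from compounds 1 and 2.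

Compound 4 `O=C(CCl)Nc1cccc(-c2nc3ccccc3s2)c1` differs from compound 3 by chloromethyl in place of 2-carboxyethenyl on a carbonyl carbon. For the measured compounds named here, no measured step bears on this change, and the values of compounds 1, 2 and 3 supply only the limit, so neither size nor direction can be taken from them. The step that the estimate means, an at least 2.0-fold lower number from compound 3 to compound 4 (0.31 log units; beyond the scatter), is expected with wide uncertainty in both directions. In this assay compound 4 is estimated at 12000 nM, with a range from 2000 nM to 25000 nM.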

Compound 4, half-maximal effective concentration: 8500 nM
Compound 4: the middle estimate sits 1.4-fold (0.15 log units) above what was measured; measured number inside the range.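

Among the compounds shown here, compound 4 is the first compound here to give a number rather than a limit in this assay, so a change on the carbonyl carbon whose other neighbour is the amide-type nitrogen can now be read. Chloromethyl in place of 2-carboxyethenyl gives an at least 2.9-fold lower number from compound 3 to compound 4 (0.46 log units; beyond the scatter), and chloromethyl in place of prop-1-en-1-yl gives an at least 2.9-fold lower number from compound 2 to compound 4 (0.46 log units; beyond the scatter). Both sizes are lower bounds, and the step between the two compounds at the limit stays unreadable: the limit of > 25000 nM in this assay, at which 3 of the 4 values shown sit.

From the compounds shown here alone, whether a methyl, bromomethyl or aminomethyl group on this carbonyl carbon would also give a number rather than a limit remains open. Going by these compounds, the full size of the two steps also remains open, with compound 2 and compound 3 each resting at a limit.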